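The source may report more compounds than this note shows. Statements on the series, on what has been measured and on what is new or still open speak of the compounds shown alone.

Compound 1 `O=C(Nc1ccc(Oc2ncnc3[nH]ncc23)cc1)Nc1ccc(C(F)(F)F)cc1` in an assay on isolated protein for inhibition of vascular endothelial growth factor receptor 2 (Danio rerio), read by fluorescence and microscopy, with a stated time of 33 h (on this read-out higher numbers stand for weaker inhibition and lower numbers for stronger inhibition), gives 1200 nM. Compound 2 `O=C(Nc1ccc(Oc2ncnc3[nH]ncc23)cc1)NC1CCCCC1` in this assay gives > 100000 nM, which is a limit of the assay rather than a number. Within the data shown here, the only measured step, an at least 83-fold higher number from compound 1 to compound 2 (1.92 log units; beyond the scatter), carries compound 2 onto (the limit of > 100000 nM in this assay, at which 1 of the 2 values shown sits), so no number marks where it truly stands. Compound 3 `O=C(NCC1CCCCC1)Nc1ccc(Oc2ncnc3[nH]ncc23)cc1` differs from compound 2 by cyclohexylmethyl in place of cyclohexyl on an amide-type nitrogen. Among the measured compounds shown here, no measured step covers a change of this kind. Because compound 2 already rests at the limit of > 100000 nM in this assay, at which 1 of the 2 values shown sits, compound 3 is expected to show a number no higher from compound 2 to compound 3 (the limit leaves the size open), nothing beyond the scatter. The estimate for compound 3 is 100000 nM, within a range from 20000 nM to 300000 nM.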

Compound 3, half-maximal inhibitory concentration: > 100000 nM
Compound 3: a limit, no number; the forecaster's own chance of this, stated with the estimate: 75%; the middle value sits exactly at the limit.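

In this assay, a second non-aromatic ring group in place of 4-(trifluoromethyl)phenyl on the amide-type nitrogen also gives a large step, an at least 83-fold higher number from compound 1 to compound 3 (1.92 log units; beyond the scatter). Compound 3 gives only a limit of the assay, so the step from cyclohexyl to cyclohexylmethyl cannot be read, and lengthening the link by cyclohexylmethyl brings no measurable number back. The values shown now gather at that limit: the limit of > 100000 nM in this assay, at which 2 of the 3 values shown sit.

Going by these compounds, whether benzyl or plain phenyl on this nitrogen would give a readable number in this assay stays open. So does how much the trifluoromethyl group itself contributes to the number of compound 1.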